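The source may hold more compounds than are shown below. What is called first, only, known or untested is meant among the compounds shown, and "the series" means these compounds.

Measured compounds:
- Compound 1 `COc1ccc(S(=O)(=O)N(CC(N)=O)c2ccc(N(CC(N)=O)S(=O)(=O)c3ccc(SCCCCCN=C=S)cc3)c3ccccc23)cc1`: > 10000 nM
- Compound 2 `COc1ccc(S(=O)(=O)N(CC(N)=O)c2ccc(N(CC(N)=O)S(=O)(=O)c3ccc([S+]([O-])CCOCCOCCOCCN=C=S)cc3)c3ccccc23)cc1`: > 10000 nM
- Compound 3 `COc1ccc(S(=O)(=O)N(CC(N)=O)c2ccc(N(CC(N)=O)S(=O)(=O)c3ccc(S(=O)(=O)CCCN=C=S)cc3)c3ccccc23)cc1`: > 10000 nM

In an ADME assay on cells (Peritoneal macrophage, Mus musculus) for cytotoxicity, read by CCK-8 assay, with a stated time of 24 h (on this read-out higher numbers stand for lower toxicity in this test and lower numbers for higher toxicity in this test), compound 1 gives > 10000 nM, and this is a limit of the assay, not a measured number. Compound 2 also gives > 10000 nM in this assay, again only a limit. Compound 3 gives > 10000 nM in this assay, once more a limit. Compound 1 therefore stands where every value shown stands, because of the limit of > 10000 nM in this assay, at which 3 of the 3 values shown sit.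

Compound 4 `COc1ccc(S(=O)(=O)N(CC(N)=O)c2ccc(N(CC(N)=O)S(=O)(=O)c3ccc(S(=O)(=O)CCCCN=C=S)cc3)c3ccccc23)cc1` differs from compound 1 in one place: a group of 10 heavy atoms (5 carbon, 1 nitrogen, 2 oxygen, 2 sulfur; no ring) in place of a group of 9 heavy atoms (6 carbon, 1 nitrogen, 2 sulfur; no ring), on an aromatic carbon. Among the measured compounds shown here, the only measured step that touches this position is a step that the two limits leave unreadable from compound 1 to compound 3, which exchanges a group on the same aromatic carbon, but since both ends sit at the limit, its size cannot be read. No step shown gives a readable change in this assay, and none points in any direction beyond the scatter.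

With every compound sitting at the limit, compound 4 is expected to sit there too, so that the estimated step that the limit leaves unreadable from compound 1 to compound 4 is in effect none that could be read. Compound 4 is thus estimated at 20000 nM in this assay, with a range from 8000 nM to 100000 nM, and most likely the assay will again report only a limit.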

Compound 4, half-maximal cytotoxic concentration: > 10000 nM
Compound 4 was reported as a limit; the forecaster's own chance of this, stated with the estimate: 85%; the middle value lies beyond the limit too.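

In this assay compound 4 gives > 10000 nM, which is a limit and not a measured number. The steps from compound 1 and from compound 3 to compound 4 cannot be read, because both ends of each sit at a limit: the limit of > 10000 nM in this assay, at which 4 of the 4 values shown sit. The compounds shown leave open whether these four differ from one another at all in this read-out, and which change of group would shift it.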